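Hydroxy for Dimethylamino: One Change Tried on Two Cores

This account rests on a few compounds, and the source may have more. Where it says the series, first, only, none or still open, it means among the compounds named here.

Compound 1 `COc1ccc(C(=O)c2ccc3c(c2)C=CC(C)(C)O3)c(NC(=O)CO)c1` and compound 2 `COc1ccc(C(=O)c2ccc3c(c2)C=CC(C)(C)O3)c(NC(=O)CN(C)C)c1` share one core and differ in a single spot: hydroxy in place of dimethylamino on a saturated chain carbon bound to a carbonyl carbon. In a functional assay on A549 cells (Homo sapiens) for antiproliferative activity, read by MTT assay, with a stated time of 48 h (on this read-out lower numbers stand for stronger inhibition and higher numbers for weaker inhibition), compound 2 gives 1160 nM and compound 1 gives 90 nM, so this change brings a 13-fold lower number from compound 2 to compound 1 (1.11 log units; beyond the scatter). Compound 3 `C=C(c1cc(OC)c(OC)c(OC)c1)c1ccc(OC)c(O)c1NC(=O)CN(C)C` is built on a different core, and the difference between the two cores is not broken down here. In this assay compound 3 gives 50 nM, a number close to that of compound 1 and well apart from that of compound 2. Compound 4 `C=C(c1cc(OC)c(OC)c(OC)c1)c1ccc(OC)c(O)c1NC(=O)CO` has not yet been measured. It arises from compound 3 by hydroxy in place of dimethylamino on a saturated chain carbon bound to a carbonyl carbon, the same change, at the same place, that turns compound 2 into compound 1. The step from compound 3 to compound 4 is expected to run in the same direction, estimated as a 2.8-fold lower number from compound 3 to compound 4 (0.44 log units; beyond the scatter). That expectation rests on a 13-fold lower number from compound 2 to compound 1 (1.11 log units; beyond the scatter). It is kept smaller than that earlier step: the change is carried over to a different core, and compound 3 already gives 50 nM. Compound 4 is therefore estimated at 18 nM, with a likely range from 5 nM to 70 nM.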

Compound 4, half-maximal inhibitory concentration: 10 nM
Compound 4: middle estimate off by 1.8-fold (0.26 log units), on the high side; low and high end bracket the measured number.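

Putting hydroxy in place of dimethylamino brings a 5.0-fold lower number from compound 3 to compound 4 (0.70 log units; beyond the scatter) in this assay, the same direction as on the other core. Set side by side, the two steps agree in direction and cannot be told apart in size: the same change on two cores in this assay, a 13-fold lower number (1.11 log units; beyond the scatter) from compound 2 to compound 1 and a 5.0-fold lower number (0.70 log units; beyond the scatter) from compound 3 to compound 4, 2.6-fold (0.41 log units) apart, within the scatter of two such steps. For the compounds shown here, this shows that the change carried over between these two cores, but with only two matched pairs it does not show that it would carry over to any further core, and these numbers do not explain why hydroxy gives the lower number.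

The compounds shown place only dimethylamino and hydroxy on a saturated chain carbon bound to a carbonyl carbon, so it remains open how a primary amine, a methoxy group or a carboxylic acid would compare there. On these data alone, a longer chain ending in hydroxy is equally open, as is whether the same step would appear in other cell lines.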